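Chloro to methyl at the same aromatic carbon

The source may hold more compounds than are shown below. What is called first, only, known or untested is meant among the compounds shown, and "the series" means these compounds.

Of the compounds shown here, three sharing one core have been measured. Compound 1 `FC(F)(F)c1ccccc1NCn1nc(-c2ccc3c(c2)OCCO3)oc1=S` gives 9220 nM in a functional assay, with a stated time of 6 min; a higher number here means a weaker inhibitor, a lower number a stronger inhibitor. Compound 2 `FC(F)(F)c1cc(NCn2nc(-c3ccc4c(c3)OCCO4)oc2=S)cc(C(F)(F)F)c1` gives 9320 nM in this assay. Compound 3 `S=c1oc(-c2ccc3c(c2)OCCO3)nn1CNc1ccc(Cl)cc1` gives 7270 nM in this assay. Compound 3 carries the lowest of the three numbers, but its gaps to compound 1 and to compound 2 both fall within the scatter, so these measurements do not separate the three compounds from one another.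

Compound 4 `Cc1ccc(NCn2nc(-c3ccc4c(c3)OCCO4)oc2=S)cc1` is not yet measured. It differs from compound 3 in one place: methyl in place of chloro on an aromatic carbon. Within the data shown here, no step between two measured compounds of this kind is available. Among the measured compounds shown here, the substituted compounds measured so far, compound 1, compound 2 and compound 3, all sit at about the same level, so changes to this ring have so far left the numbers close together. For compound 4 the step of a 1.1-fold higher number from compound 3 to compound 4 (0.04 log units; within the scatter) is expected to be small, in no sure direction, and not beyond the scatter. Compound 4 is estimated at 8000 nM in this assay, with a range from 4000 nM to 16000 nM.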

Compound 4, half-maximal inhibitory concentration: 5700 nM
Compound 4: middle estimate off by 1.4-fold (0.15 log units), on the high side; the measured number falls inside the stated range.
By their numbers in this assay, from the lowest: compounds 4, 3, 1 and 2 (each within the scatter of the next).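

Among these compounds, the exchange of chloro for methyl at this aromatic carbon, para to a large group, gives the first directly readable step at this position in this assay, with a 1.3-fold lower number from compound 3 to compound 4 (0.11 log units; within the scatter) as the result. With this step inside the scatter, 4-chlorophenyl and 4-methylphenyl cannot be told apart in this assay, so this exchange of one heavy atom for another leaves compound 3 and compound 4 unseparated. No measurement is available that bears on this result.

Still open, from the compounds shown here alone, is whether a group of another kind at this position, such as an amine, a carboxylic acid or a longer chain, would give a step beyond the scatter. Also open, going by these compounds, is whether the same exchange of chloro for methyl would read alike on a different core.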